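Adding methoxy to compound 1: solubility expectation

The source may report more compounds than this note shows. Statements on the series, on what has been measured and on what is new or still open speak of the compounds shown alone.

Compound 1 `FC(F)(F)c1cccc(-c2nc3cnc(Nc4ccccn4)cc3[nH]2)c1` gives < 5000 nM in a physicochemical assay for solubility, using the shake flask method, in phosphate buffer, measured as kinetic solubility, with a stated time of 20 h, at pH 6.5 (a higher number here means a more soluble compound, a lower number a less soluble compound), which is a limit rather than a number.
Compound 2 `FC(F)(F)Oc1ccc(-c2nc3cnc(Nc4ccccn4)cc3[nH]2)cc1` gives < 5000 nM in this assay, again a limit rather than a number.

Within the data shown here, compound 1 thus stands at the limit, and the only other value sits there too (the limit of < 5000 nM in this assay, at which 2 of the 2 values shown sit). Compound 3 `COc1cccc(Nc2cc3[nH]c(-c4cccc(C(F)(F)F)c4)nc3cn2)n1` differs from compound 1 by methoxy in place of hydrogen on an aromatic carbon. Among the measured compounds shown here, no measured step exists, so the expected step that the limit leaves unreadable from compound 1 to compound 3 is set to none beyond the scatter. Compound 3 is therefore estimated at 3000 nM, within 700 nM to 9000 nM, most likely reported again as a limit.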

Compound 3, solubility: < 5000 nM
Compound 3: only a limit was reported; the forecaster's own chance of this, stated with the estimate: 80%; the middle value lies beyond the limit too.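

Compound 1 and compound 3 each give only a limit, so no step between them can be read: the limit of < 5000 nM in this assay, at which 3 of the 3 values shown sit.

The compounds shown leave open how soluble each one actually is, and whether 6-methoxypyridin-2-yl in place of pyridin-2-yl changes that at all.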